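A few compounds are considered here, and "the series" means these few. Any claim that something is new, unique, unknown or untested is made for them only; others in the source may bear on it.

Compound 1 `Cc1cc(NCCCCNc2ccnc3cc(Cl)ccc23)nc(N2CCN(C)CC2)n1` was tested in an ADME assay on HepG2 cells (Homo sapiens) for cytotoxicity, read by neutral red uptake, with a stated time of 48 h (a lower number here means a stronger inhibitor, a higher number a weaker inhibitor), where compound 1 gives 29500 nM. This is the higher of the two numbers seen so far: compound 2 `Cc1cc(NCCCCCCNc2ccnc3cc(Cl)ccc23)nc(Cl)n1` gives 9100 nM, a lower number that lies beyond the usual scatter. Compound 3 `CCN1CCN(c2nc(C)cc(NCCCCNc3ccnc4cc(Cl)ccc34)n2)CC1` has not yet been measured in this assay. It differs from compound 1 in one place: methyl in place of hydrogen on a saturated chain carbon bound to an amine nitrogen in a ring. Among the measured compounds shown here, no measured pair shows this same change, so the expectation rests on the small size of the change alone, and the step of a 1.2-fold lower number from compound 1 to compound 3 (0.07 log units; within the scatter) is expected to stay within the scatter. Compound 3 is accordingly estimated at 25000 nM, with a range from 12000 nM to 60000 nM.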

Compound 3, half-maximal inhibitory concentration: 15400 nM
For compound 3 the middle estimate is 1.6-fold (0.21 log units) above the measured one, within the range that was stated.
By their numbers in this assay, from the lowest: compounds 2, 3 and 1 (each within the scatter of the next, the first and the last beyond it).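

Among the compounds shown here, at this place, on a saturated chain carbon bound to an amine nitrogen in a ring, the change from 4-methylpiperazin-1-yl to 4-ethylpiperazin-1-yl gives the first comparison in this assay of compounds that differ in one place: a 1.9-fold lower number from compound 1 to compound 3 (0.28 log units; within the scatter). This single added methyl therefore leaves the two compounds within the scatter of each other, though one pair sets no pattern. No available evidence bears on this result. The compounds shown leave open how a longer chain such as propyl, or a carboxylic acid, would read at this same place.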